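This account rests on a few compounds, and the source may have more. Where it says the series, first, only, none or still open, it means among the compounds named here.

In a functional assay on A549 cells (Homo sapiens) for antiproliferative activity, read by MTT assay, with a stated time of 48 h (on this read-out higher numbers stand for weaker inhibition and lower numbers for stronger inhibition), two compounds with a shared core have been measured so far. Compound 1 `Fc1ccc(-c2nn(-c3ccccc3)cc2-c2nc3cc(Br)ccc3[nH]2)cc1` gives 5830 nM, and compound 2 `COc1ccc2[nH]c(-c3cn(-c4ccccc4)nc3-c3ccc(F)cc3)nc2c1` gives 1960 nM. Within the data shown here, compound 2 therefore holds the lower of the two numbers, and the only measured step is a 3.0-fold lower number from compound 1 to compound 2 (0.47 log units; beyond the scatter), with methoxy in place of bromo on an aromatic carbon.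

The next compound is compound 3 `COc1ccc2[nH]c(-c3cn(-c4ccccc4)nc3-c3ccc(Cl)cc3)nc2c1`, which has chloro in place of fluoro on an aromatic carbon. The change sits on a six-membered aromatic ring of carbon only, para to a large group, and reads as 4-fluorophenyl to 4-chlorophenyl. Among the measured compounds shown here, no measured step touches this place, so the data give no direct guide to it. For the measured compounds named here, the one step available, a 3.0-fold lower number from compound 1 to compound 2 (0.47 log units; beyond the scatter), was modest and involved a different exchange, so it bears on the new change only loosely, as a rough ceiling on size. No step beyond the scatter is therefore expected in this assay, in either direction. The expected step is a 1.1-fold lower number from compound 2 to compound 3 (0.04 log units; within the scatter). For compound 3 the estimated value is 1800 nM, within an expected range of 700 nM to 4800 nM.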

Compound 3, half-maximal inhibitory concentration: 2420 nM
The estimate for compound 3 lay 1.3-fold (0.13 log units) below the measured number; low and high end bracket the measured number.
By their numbers in this assay, from the lowest: compounds 2 and 3 (each within the scatter of the next); then compound 1.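

In this assay, chloro in place of fluoro gives a 1.2-fold higher number from compound 2 to compound 3 (0.09 log units; within the scatter), so compound 2 and compound 3 cannot be told apart on this read-out. Among these compounds, this is the first reading at this place, on an aromatic carbon of a six-membered aromatic ring of carbon only, para to a large group, and it shows that, for these two halogens, the choice between 4-fluorophenyl and 4-chlorophenyl leaves the number within the usual scatter, whereas the one earlier step concerned methoxy and bromo at a different place and said nothing about this one. Nothing available explains why the two halogens read alike.

From the compounds shown here alone, with only fluoro and chloro seen at this place, it remains open whether a group of a different kind there, such as an amine, a carboxylic acid or a longer chain, would also leave the number within the scatter or move it clearly in either direction. Going by these compounds, it is also open whether the exchange of fluoro for chloro would read the same way with bromo in place of methoxy at the other position.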